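Swapping the Heteroaryl Group on the Saturated Ring Carbon

A few compounds are considered here, and "the series" means these few. Any claim that something is new, unique, unknown or untested is made for them only; others in the source may bear on it.

Compound 1, `CC[C@H](C)[C@H](N)CN(C(=O)[C@@H]1C[C@H]1c1ccc(F)c(F)c1)c1ccc(-c2ccccc2)cc1`: 720 nM
Compound 2, `CC[C@H](C)[C@H](N)CN(C(=O)[C@@H]1C[C@H]1c1ccncc1)c1ccc(-c2ccccc2)cc1`: 1500 nM

Both compounds share the same core and differ only in the aromatic group attached to a saturated ring carbon. In a functional assay for agonist activity at G protein-coupled receptor 88 (Homo sapiens), read by HTRF and cAMP accumulation (on this read-out lower numbers stand for an effect already at smaller amounts and higher numbers for an effect only at larger amounts of compound), compound 1 gives 720 nM, and in this assay compound 2 gives 1500 nM. Among the two numbers, compound 2 stands highest; its nearest neighbour is compound 1, and the only step so far, a 2.1-fold higher number from compound 1 to compound 2 (0.32 log units; beyond the scatter), is a modest shift to a higher number, beyond the scatter.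

Compound 3, `CC[C@H](C)[C@H](N)CN(C(=O)[C@@H]1C[C@H]1c1ncc(C)s1)c1ccc(-c2ccccc2)cc1`, differs from compound 2 by one change: 5-methyl-1,3-thiazol-2-yl in place of pyridin-4-yl on a saturated ring carbon. Going by the values given here, no measured pair exchanges one heteroaryl group for another, so the single step at this place, a 2.1-fold higher number from compound 1 to compound 2 (0.32 log units; beyond the scatter), is the only guide, and it concerns a different pair of groups. The replacement keeps the size of the group and adds a hydrogen-bond acceptor, but nothing measured shows what that does here. For compound 3 in this assay no step beyond the scatter is expected, with a 1.2-fold lower number from compound 2 to compound 3 (0.06 log units; within the scatter) as the expected change. Compound 3 is therefore estimated at 1300 nM, within a range from 450 nM to 4000 nM.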

Compound 3, half-maximal effective concentration: 1300 nM
The estimate for compound 3 equals the measured number at the digits printed, within the range that was stated.
By their numbers in this assay, from the lowest: compounds 1, 3 and 2 (each within the scatter of the next, the first and the last beyond it).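

Read in this assay, putting 5-methyl-1,3-thiazol-2-yl in place of pyridin-4-yl gives a 1.2-fold lower number from compound 2 to compound 3 (0.06 log units; within the scatter), so at this position the result does not separate a six-membered aromatic ring with 1 hetero atom from a five-membered aromatic ring with 2 hetero atoms, even though the entering group counts one more hydrogen-bond acceptor. Putting the same group in place of 3,4-difluorophenyl gives a 1.8-fold higher number from compound 1 to compound 3 (0.26 log units; within the scatter), which places compound 3 within the scatter of both earlier compounds, although the two earlier compounds are separated by a 2.1-fold higher number from compound 1 to compound 2 (0.32 log units; beyond the scatter). No independent measurement is available to explain these results.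

As far as these compounds go, what an amine or a carboxylic acid would do in place of the aromatic group on this saturated ring carbon remains open. From the compounds shown here alone, the contribution of the methyl group in compound 3 is also open, as it could be judged only against the plain 1,3-thiazol-2-yl group on the shared core.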